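The source may report more compounds than this note shows. Statements on the series, on what has been measured and on what is new or still open speak of the compounds shown alone.

Measured compounds in a functional assay on aorta for antagonist activity at thromboxane A2 receptor (Rattus norvegicus); a higher number here means weaker binding, a lower number tighter binding:
compound 1 `Cc1ccc(S(=O)(=O)Nc2ccc3c(c2)c(Cc2ccc(F)cc2)cn3CCC(=O)O)cc1`: 0.269 nM
compound 2 `O=C(O)CCCc1ccc(NS(=O)(=O)c2ccc(Cl)cc2)cc1`: 100 nM

Compound 1 gives the lowest of the two numbers in this assay; the nearest, compound 2, lies far higher, beyond the scatter. Going by the values given here, no single-point step between measured compounds is available.

Compound 3 `COc1ccc(S(=O)(=O)Nc2ccc3c(c2)c(Cc2ccc(F)cc2)cn3CCC(=O)O)cc1` differs from compound 1 by methoxy in place of methyl on an aromatic carbon, in words methoxy in place of methyl on an aromatic carbon. Among the compounds with values here, with no comparable step measured, the change from compound 1 to compound 3 is expected to stay within the scatter, as a 1.2-fold higher number from compound 1 to compound 3 (0.08 log units; within the scatter). Compound 3 is therefore estimated at 0.32 nM, within 0.1 nM to 1 nM.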

Compound 3, dissociation constant: 0.174 nM
Compound 3: the middle estimate sits 1.8-fold (0.26 log units) above what was measured; the range from low to high includes it.
By their numbers in this assay, from the lowest: compounds 3 and 1 (each within the scatter of the next); then compound 2.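

In this assay, going by these compounds alone, methoxy in place of methyl on an aromatic carbon, para to a large group, gives a 1.5-fold lower number from compound 1 to compound 3 (0.19 log units; within the scatter) and so provides the first single-point reading. At this position, the 4-methylphenyl to 4-methoxyphenyl change adds one heavy atom and one hydrogen-bond acceptor without a shift beyond the scatter. Nothing available explains this result.

Still open, on these data alone, is whether an amine, a nitrile or a longer chain such as ethoxy at this position would also stay within the scatter of compound 1.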